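The source may report more compounds than this note shows. Statements on the series, on what has been measured and on what is new or still open speak of the compounds shown alone.

Measured in a functional assay for inhibition, with Rattus norvegicus as the target; on this read-out lower numbers stand for an effect already at smaller amounts and higher numbers for an effect only at larger amounts of compound:
- compound 1 `CSCC[C@H](NC(=O)c1ccc(CN[C@H](CO)CC2CCCCC2)cc1-c1ccccc1C)C(=O)O`: 190 nM
- compound 2 `CSCC[C@H](NC(=O)c1ccc(CN(CCC2CCCCC2)C(=O)c2ccccc2)cc1-c1ccccc1C)C(=O)O`: > 1000 nM (a limit)
- compound 3 `CSCC[C@H](NC(=O)c1ccc(CN(CCC2CCCCC2)Cc2ccccc2)cc1-c1ccccc1C)C(=O)O`: > 1000 nM (a limit)

Compound 3 has no number, only a limit, and it belongs to the limit of > 1000 nM in this assay, at which 2 of the 3 values shown sit. Compound 4 `CSCC[C@H](NC(=O)c1ccc(CN(C)CCC2CCCCC2)cc1-c1ccccc1C)C(=O)O` differs from compound 3 by hydrogen in place of phenyl on a saturated chain carbon bound to an amine nitrogen, which reads as benzyl to methyl. Among the measured compounds shown here, the one measured step bearing on this group is a step that the two limits leave unreadable from compound 2 to compound 3, so no measured size carries over. For the measured compounds named here, the only number belongs to compound 1 at 190 nM, and on that value rests a tentative expectation of a move towards lower numbers. The expected step is an at least 1.6-fold lower number from compound 3 to compound 4 (0.22 log units; that floor lies within the scatter). For compound 4 the estimate is 600 nM, with an expected range of 150 nM to 2500 nM.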

Compound 4, half-maximal effective concentration: 12 nM
Estimate against measurement, compound 4: 50-fold (1.70 log units) above; the measured number lies below the stated range.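

In this assay, hydrogen in place of phenyl on a saturated chain carbon bound to an amine nitrogen, read as benzyl to methyl, gives an at least 83-fold lower number from compound 3 to compound 4 (1.92 log units; beyond the scatter). Methyl in place of benzoyl on the amine nitrogen gives an at least 83-fold lower number from compound 2 to compound 4 (1.92 log units; beyond the scatter), and both sizes rest on a limit rather than a number: the limit of > 1000 nM in this assay, at which 2 of the 4 values shown sit. The change at the saturated chain carbon bound to an aromatic carbon also gives a 16-fold lower number from compound 1 to compound 4 (1.20 log units; beyond the scatter), which places the lowest number of the series with methyl on this nitrogen.

From the compounds shown here alone, whether ethyl, a longer chain or hydrogen on this nitrogen keeps that number stays open. The step between the two limits cannot be read.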